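This account rests on a few compounds, and the source may have more. Where it says the series, first, only, none or still open, it means among the compounds named here.

Measured compounds and their readings:
- compound 1 `O=C(NC(=S)Nc1nc[nH]n1)c1ccccc1`: > 100000 nM, a limit of the assay rather than a number.
- compound 2 `COc1ccc(NC(=S)Nc2nc[nH]n2)cc1`: > 100000 nM, again a limit.
- compound 3 `Fc1ccc(NC(=S)Nc2nc[nH]n2)cc1`: > 100000 nM, again a limit.

In an ADME assay on MT4 cells (Homo sapiens) for cytotoxicity, read by MTT assay, with a stated time of 96 h (on this read-out lower numbers stand for higher toxicity in this test and higher numbers for lower toxicity in this test), every reading so far sits at the same ceiling, as the limit of > 100000 nM in this assay, at which 3 of the 3 values shown sit, states. Compound 3 therefore stands at that limit, not at a measured number. The only step among these compounds, a step that the two limits leave unreadable from compound 2 to compound 3, has both ends at the limit and so gives no readable size.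

Compound 4 `S=C(Nc1ccc(I)cc1)Nc1nc[nH]n1` differs from compound 3 by iodo in place of fluoro on an aromatic carbon. Among the compounds with values here, no measured step bears on this change, and nothing seen so far moves off the ceiling, so compound 4 is expected to show no step beyond the scatter, a step that the limit leaves unreadable from compound 3 to compound 4, in this assay. The estimate for compound 4 is 150000 nM, within 50000 nM to 400000 nM, most likely reported once more as a limit.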

Compound 4, half-maximal cytotoxic concentration: 46000 nM
For compound 4 the middle estimate is 3.3-fold (0.51 log units) above the measured one, outside the stated range (below it).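

Iodo in place of fluoro is the first change here that moves a reading off the ceiling in this assay, with an at least 2.1-fold lower number from compound 3 to compound 4 (0.33 log units; beyond the scatter), and iodo in place of methoxy gives an at least 2.1-fold lower number from compound 2 to compound 4 (0.33 log units; beyond the scatter). So the group on this aromatic carbon can matter, and the lower number stands for higher toxicity in this test. The full size of both steps cannot be read because each starts from a limit: the limit of > 100000 nM in this assay, at which 3 of the 4 values shown sit.

From the compounds shown here alone, whether chloro or bromo would also lower the number remains open. So does the effect of an amine or a carboxylic acid on this carbon.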